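Swapping Carboxymethyl for Isopropyl on the Side Chain

The compounds below may be only part of what the source reports. "The series", "measured", "known", "first", "only" and "open" are said of these compounds alone.

Measured so far:
- compound 1, `O=C(O)CC[C@H](NC(=O)CN(c1nc(Cl)nc2[nH]cnc12)C1CC1)C(=O)O`: 44.7% in a functional assay on the whole organism (Tail, strain ICR) with Mus musculus as the target, in the tail flick test, with a stated time of 90 min, at a dose of 25 umol/kg by the oral route; a lower number here means a weaker effect, a higher number a stronger effect of the compound at the dose given
- compound 2, `NC(=O)C[C@H](NC(=O)CN(c1ncnc2c1ncn2C1CCCCO1)C1CC1)C(=O)OCc1ccccc1`: 35% in this assay

Of the compounds shown here, two have been tested in this assay. Compound 1 holds the larger of the two numbers recorded, but its gap to compound 2 falls within the usual scatter of this measurement, so the two cannot be told apart on these data. Compound 2 also differs from compound 1 in several places at once, so nothing can be read from that pair about any single change.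

Compound 3, `CC(C)C[C@H](NC(=O)CN(c1nc(Cl)nc2[nH]cnc12)C1CC1)C(=O)O`, has not yet been measured. It differs from compound 1 in one place: isopropyl in place of carboxymethyl on a saturated chain carbon, two bonds along the chain from an amide-type nitrogen and a carbonyl carbon. One hydrogen-bond donor and one hydrogen-bond acceptor leave with the carboxymethyl group, and isopropyl enters without either. Among the measured compounds shown here, no measured pair shows the effect of this change, so the expectation rests on compound 1 alone.

The step of a number 2.7 percentage points lower from compound 1 to compound 3 (within the scatter) is expected to stay within the scatter, with no clear direction. Compound 3 is therefore estimated at 42%, within a range from 20% to 64%.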

Compound 3, a percentage reported as activity, at one dose (the size of the read-out at that dose, not a potency): 27%
Beside the measured number, compound 3's estimate is 15 percentage points above it; the range from low to high includes it.
By their numbers in this assay, from the lowest: compounds 3, 2 and 1 (each within the scatter of the next, the first and the last beyond it).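

In this assay, among the compounds shown here, isopropyl in place of carboxymethyl on a saturated chain carbon, two bonds along the chain from an amide-type nitrogen and a carbonyl carbon, gives the first single change that can be read (a number 17.7 percentage points lower from compound 1 to compound 3 (beyond the scatter)). The earlier pair could not show this, since compound 2 differs from compound 1 in several places at once, so this side chain is now known to matter to the size of the effect, with the rest of the structure held the same. The change takes away a hydrogen-bond donor and a hydrogen-bond acceptor along with the carboxymethyl group, but no measurement available here says what lies behind the modest loss.

The compounds shown leave open whether the carboxylic acid itself matters or only the chain that carries it: a primary amide, a methyl ester or an aminomethyl group at this place would help to separate the two. From the compounds shown here alone, a longer chain ending in a carboxylic acid is also open, and since each number is a read-out at one dose, how potent these compounds are remains unknown.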